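The source may report more compounds than this note shows. Statements on the series, on what has been measured and on what is new or still open speak of the compounds shown alone.

Measured in a functional assay, read by spectrophotometry, with a stated time of 5 min; a lower number here means a stronger inhibitor, a higher number a weaker inhibitor:
- Compound 1 `CCOc1cc(/C=C/C(=O)C(=Cc2ccc(OC)c(OC)c2)C(=O)/C=C/c2ccc(O)c(OCC)c2)ccc1O`: 11300 nM
- Compound 2 `CCOc1cc(/C=C/C(=O)C(=Cc2ccc(OCC)c(OCC)c2)C(=O)/C=C/c2ccc(O)c(OCC)c2)ccc1O`: 20200 nM

Only these two compounds have been measured so far. Compound 2, at 20200 nM, cannot be told apart from compound 1, at 11300 nM, since the two values lie within the scatter of each other.

The next compound, compound 3 `CCOc1cc(/C=C/C(=O)C(=Cc2ccccc2)C(=O)/C=C/c2ccc(O)c(OCC)c2)ccc1O`, differs from compound 2 in one place: phenyl in place of 3,4-diethoxyphenyl on a double-bonded chain carbon bound to a double-bonded chain carbon. This puts phenyl in place of 3,4-diethoxyphenyl on a double-bonded chain carbon bound to a double-bonded chain carbon.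

For the measured compounds named here, one measured step bears on this change, as it falls at the same place: a 1.8-fold higher number from compound 1 to compound 2 (0.25 log units; within the scatter). That step lies within the scatter. However, it only exchanges 3,4-dimethoxyphenyl for 3,4-diethoxyphenyl, and no measured compound carries phenyl at this place. The data therefore give no direction in this assay, and no step beyond the scatter is expected. The estimate is a 1.4-fold lower number from compound 2 to compound 3 (0.16 log units; within the scatter), an expected change that stays small but is uncertain. For compound 3 the expected value is 14000 nM, with an estimated range of 5000 nM to 40000 nM.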

Compound 3, half-maximal inhibitory concentration: 20400 nM
Compound 3: middle estimate off by 1.5-fold (0.16 log units), on the low side, and the stated range covers the measured number.
By their numbers in this assay, from the lowest: compounds 1, 2 and 3 (each within the scatter of the next).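

In this assay, phenyl on a double-bonded chain carbon bound to a double-bonded chain carbon cannot be told apart from 3,4-diethoxyphenyl (a 1.0-fold higher number from compound 2 to compound 3 (0.00 log units; within the scatter)) or from 3,4-dimethoxyphenyl (a 1.8-fold higher number from compound 1 to compound 3 (0.26 log units; within the scatter)). For the compounds shown here, the earlier pair compared only two rings that both carried oxygen substituents, whereas compound 3 has a phenyl of 6 heavy atoms and no hydrogen-bond acceptors, against 12 heavy atoms and 2 acceptors in the 3,4-diethoxyphenyl of compound 2, so across these three compounds neither substituent oxygens nor the extra heavy atoms on this ring produce a difference beyond the scatter. No measurement is available that explains why the three compounds cannot be separated.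

From the compounds shown here alone, it remains open whether any group at this place would give a step beyond the scatter, such as a phenyl bearing an amine or a carboxylic acid, or a longer alkyl chain in place of the ring. Going by these compounds, the rest of the core is the same in all three compounds, so what its parts contribute in this assay also remains open.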